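Swapping a cyclopentyl for isopropyl on the ketone side chain

This account rests on a few compounds, and the source may have more. Where it says the series, first, only, none or still open, it means among the compounds named here.

Measured so far:
compound 1, `Cc1c(OCCCCOc2ccc(C(=O)O)cc2Cl)ccc(C(=O)CC2CCCC2)c1O`, 27.4%;
compound 2, `Cc1c(OCCCCOc2cccc(C(=O)O)c2)ccc(C(=O)CC(C)C)c1O`, 69.9%;
compound 3, `Cc1cc(OCCCCOc2ccc(C(=O)CC3CCCC3)c(O)c2C)ccc1C(=O)O`, 23.7%.

In an assay on HEK293 cells for positive allosteric modulation of metabotropic glutamate receptor 3 (Rattus norvegicus), read by thallium flux, with a stated time of 2.5 min (a higher number here means a larger maximal response, a lower number a smaller maximal response), compound 3 gives the lowest of the three numbers. Its nearest neighbour is compound 1, and the step of a number 3.7 percentage points lower from compound 1 to compound 3 (within the scatter) lies within the scatter, so these two cannot be told apart. Compound 2 stands far higher, but it differs from compound 3 in two places at once, so its value alone cannot say which change matters.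

Compound 4, `Cc1cc(OCCCCOc2ccc(C(=O)CC(C)C)c(O)c2C)ccc1C(=O)O`, has not yet been measured. It differs from compound 3 only in this: isopropyl in place of cyclopentyl on a saturated chain carbon bound to a carbonyl carbon. Within the data shown here, no measured step isolates this change. Among the measured compounds shown here, the only hint is that compound 2, which also carries the isopropyl, sits well above compound 3; yet compound 2 also carries a different acid-bearing ring, so the hint is weak. A modest rise is therefore expected: a number 21.3 percentage points higher from compound 3 to compound 4 (beyond the scatter). Compound 4 is estimated at 45%, with a range from 25% to 70%.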

Compound 4, largest response reached (reported as percent of maximum), in percent of the reference or control that the assay uses: 41.9%
Compound 4: the middle estimate sits 3.1 percentage points above what was measured, and the stated range covers the measured number.
By their numbers in this assay, from the lowest: compounds 3 and 1 (each within the scatter of the next); then compound 4; then compound 2.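

In this assay, the step of a number 18.2 percentage points higher from compound 3 to compound 4 (beyond the scatter) isolates the side chain: with the acid-bearing ring held fixed, isopropyl in place of cyclopentyl raises the maximal response on its own. The step of a number 28 percentage points lower from compound 2 to compound 4 (beyond the scatter) isolates the other change: with isopropyl held fixed, 4-carboxy-3-methylphenyl in place of 3-carboxyphenyl lowers the response, so both places move the number and the large gap between compound 2 and compound 3 is not the work of the side chain alone. Nothing measured here explains why either change moves the response.

Still open, going by these compounds, is whether cyclopentyl to isopropyl gives a similar rise when the acid-bearing group is 3-carboxyphenyl. Also open, on these data alone, is how a smaller methyl or a larger cyclohexyl would read at this place on the saturated chain carbon.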